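From methylsulfonyl to 2-sulfoethyl on the amide nitrogen

The compounds below may be only part of what the source reports. "The series", "measured", "known", "first", "only" and "open" are said of these compounds alone.

Compound 1 `O=C(O)c1cccc([C@H]2C[C@@H](c3ccc(OCc4c(-c5c(Cl)cccc5Cl)noc4C4CC4)cc3Cl)C2)c1` gives 92 nM in an assay on HEK293 cells for agonist activity at Bile acid receptor (Homo sapiens); on this read-out higher numbers stand for an effect only at larger amounts of compound and lower numbers for an effect already at smaller amounts.
Compound 2 `CCO[C@]1(c2ccc(OCc3c(-c4c(Cl)cccc4Cl)noc3C3CC3)cc2Cl)C[C@H](c2cccc(C(=O)O)c2)C1` gives 220 nM in this assay.
Compound 3 `CS(=O)(=O)NC(=O)c1ccc(C2CC2c2ccc(OCc3c(-c4c(Cl)cccc4Cl)noc3C3CC3)cc2Cl)cc1` gives 44 nM in this assay.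

Compound 3 stands at the lowest of these three numbers; compound 1 is its nearest neighbour and compound 2 the furthest, both with higher numbers and both beyond the scatter. Within the data shown here, the single measured step, a 2.4-fold higher number from compound 1 to compound 2 (0.38 log units; beyond the scatter), concerns a saturated ring shared by compound 1 and compound 2 and touches no part of the change considered here.

Compound 4 `O=C(NCCS(=O)(=O)O)c1ccc(C2CC2c2ccc(OCc3c(-c4c(Cl)cccc4Cl)noc3C3CC3)cc2Cl)cc1` differs from compound 3 by 2-sulfoethyl in place of methylsulfonyl on an amide-type nitrogen. Among the measured compounds shown here, no measured step bears on this change, so the expectation rests on the size of the change alone: the group that enters is larger and brings a hydrogen-bond donor, yet the surrounding structure of compound 3 is kept intact. The expected step is a 1.8-fold higher number from compound 3 to compound 4 (0.26 log units; within the scatter), a modest move towards a higher number that may not exceed the scatter. Compound 4 is therefore estimated to give 80 nM in this assay, with a range from 25 nM to 300 nM.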

Compound 4, half-maximal effective concentration: 1370 nM
The estimate for compound 4 lay 17-fold (1.23 log units) below the measured number, and the stated range ends below it.
By their numbers in this assay, from the lowest: compound 3; then compound 1; then compound 2; then compound 4.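

The amide-type nitrogen proves to be a sensitive place in this assay: a 31-fold higher number from compound 3 to compound 4 (1.49 log units; beyond the scatter) follows when 2-sulfoethyl takes the place of methylsulfonyl, a large step beyond the scatter. The earlier compounds shown here offered only a step on a saturated ring, a 2.4-fold higher number from compound 1 to compound 2 (0.38 log units; beyond the scatter), and so gave no reading at this nitrogen. The compounds shown offer nothing that accounts for the size of this new step.

From the compounds shown here alone, it remains open whether the higher number goes with the sulfo group itself or with the chain that carries it. How a carboxylic acid on the same chain, a plain ethyl group or a longer chain ending in a sulfo group would read on this nitrogen also remains an open question.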